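The source may hold more compounds than are shown below. What is called first, only, known or untested is meant among the compounds shown, and "the series" means these compounds.

Compound 1 `CN(C)CC(=O)N1CCC(NS(=O)(=O)c2cc(S(=O)(=O)c3ccccc3)ccc2C(F)(F)F)CC1`: 100000 nM
Compound 2 `O=C(Cn1ccnc1)N1CCC(NS(=O)(=O)c2cc(S(=O)(=O)c3ccccc3)ccc2C(F)(F)F)CC1`: 100000 nM

In a physicochemical assay for solubility (a higher number here means a more soluble compound, a lower number a less soluble compound), compound 2 reads 100000 nM, level with compound 1 at the digits shown. The next structure, compound 3 `CC(C)(C)OC(=O)N1CCC[C@@H]1C(=O)N1CCC(NS(=O)(=O)c2cc(S(=O)(=O)c3ccccc3)ccc2C(F)(F)F)CC1`, keeps the shared core and changes the group on the carbonyl carbon: 1-(tert-butoxycarbonyl)pyrrolidin-2-yl in place of (1H-imidazol-1-yl)methyl on a carbonyl carbon. In words, 1-(tert-butoxycarbonyl)pyrrolidin-2-yl stands in place of (1H-imidazol-1-yl)methyl on a carbonyl carbon.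

Going by the values given here, only one measured step bears on this change, namely no change at the digits printed from compound 1 to compound 2 (within the scatter). That step lies within the scatter, but it exchanged only the group on a saturated chain carbon bound to a carbonyl carbon. The new change replaces that chain carbon as well and brings in a much larger group. Among the compounds with values here, the two measured compounds therefore give weak guidance, and no measured step of this kind exists. A fall in this assay is nevertheless expected, with the expected step being a 3.3-fold lower number from compound 2 to compound 3 (0.52 log units; beyond the scatter). For compound 3 the estimated value is 30000 nM, with an expected range from 5000 nM to 100000 nM.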

Compound 3, solubility: 25000 nM
For compound 3 the middle estimate is 1.2-fold (0.08 log units) above the measured one; measured number inside the range.
By their numbers in this assay, from the lowest: compound 3; then compounds 1 and 2 (each within the scatter of the next).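

In this assay, the group on the carbonyl carbon can move the read-out: 1-(tert-butoxycarbonyl)pyrrolidin-2-yl in place of (1H-imidazol-1-yl)methyl gives a 4.0-fold lower number from compound 2 to compound 3 (0.60 log units; beyond the scatter), and in place of (dimethylamino)methyl it gives a 4.0-fold lower number from compound 1 to compound 3 (0.60 log units; beyond the scatter). The earlier pair had shown only no change at the digits printed from compound 1 to compound 2 (within the scatter), so this is the first step at this position to lie beyond the scatter, and it is read the same way from either of the two earlier compounds. No measurement shown here accounts for the fall.

The entering group differs from both groups it replaces in several ways at once, with 12 heavy atoms, a five-membered non-aromatic ring, a double bond outside aromatic rings and a defined stereocentre, so the three compounds do not assign the step to any one of these features. As far as these compounds go, it remains open whether the pyrrolidin-2-yl group with a free ring amine, lacking the tert-butoxycarbonyl group, would read with compound 3 or level with compounds 1 and 2, and whether the opposite configuration at the stereocentre would give the same number.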